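The compounds below may be only part of what the source reports. "The series", "measured", "known", "first", "only" and "open" are said of these compounds alone.

Compound 1, `O=C(O)c1ccc(N(Cc2ccc(C3CCCCC3)cc2)C(=O)[C@H]2CCN2S(=O)(=O)c2c(F)c(F)c(F)c(F)c2F)c(F)c1`, in a functional assay on MDA-MB-231 cells (Homo sapiens) for antiproliferative activity, with a stated time of 72 h (a higher number here means that more compound is needed for the effect, a lower number that less compound is needed), gives a limit and not a number: > 10000 nM.
Compound 2, `COC(=O)c1ccc(N(Cc2ccc(C3CCCCC3)cc2)C(=O)[C@H]2CCN2S(=O)(=O)c2c(F)c(F)c(F)c(F)c2F)c(F)c1`, in this assay gives 4400 nM.

Compound 2 holds the only number shown in this assay; the further value is a limit. Among the measured compounds shown here, the single measured step is an at least 2.2-fold lower number from compound 1 to compound 2 (0.35 log units; beyond the scatter), and it is anchored on one side by the limit of > 10000 nM in this assay, at which 1 of the 2 values shown sits. Compound 3, `O=C(NO)c1ccc(N(Cc2ccc(C3CCCCC3)cc2)C(=O)[C@H]2CCN2S(=O)(=O)c2c(F)c(F)c(F)c(F)c2F)cc1O`, differs from compound 2 by 3-hydroxy-4-(hydroxycarbamoyl)phenyl in place of 2-fluoro-4-(methoxycarbonyl)phenyl on an amide-type nitrogen. For the measured compounds named here, the measured step touches only the methyl in place of hydrogen on an oxygen next to a carbonyl group, so it does not bear on the exchange of the whole 3-hydroxy-4-(hydroxycarbamoyl)phenyl for the 2-fluoro-4-(methoxycarbonyl)phenyl, and no other measured pair speaks to it. The expectation therefore rests on compound 2 alone and carries wide bounds, with no step beyond the scatter foreseen in either direction. Compound 3 is expected at 3500 nM (from 600 nM to 15000 nM), which is an expected step of a 1.3-fold lower number from compound 2 to compound 3 (0.10 log units; within the scatter).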

Compound 3, half-maximal effective concentration: 5100 nM
For compound 3 the middle estimate is 1.5-fold (0.16 log units) below the measured one, within the range that was stated.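

In this assay, among the compounds shown here, the exchange of the whole group on the amide-type nitrogen, 3-hydroxy-4-(hydroxycarbamoyl)phenyl for 2-fluoro-4-(methoxycarbonyl)phenyl, gives a 1.2-fold higher number from compound 2 to compound 3 (0.06 log units; within the scatter), so compound 3 cannot be told apart from compound 2, and the methoxycarbonyl group is no longer the only group with a measured number at this position. Set against the 4-carboxy-2-fluorophenyl group, the same entering group gives an at least 1.9-fold lower number from compound 1 to compound 3 (0.29 log units; that floor lies within the scatter), so compound 3 cannot be firmly separated from compound 1. The value of compound 1 is a limit and not a number, and this sets that floor: the limit of > 10000 nM in this assay, at which 1 of the 3 values shown sits.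

From the compounds shown here alone, the hydroxy group, the hydroxycarbamoyl group and the loss of fluorine enter together in compound 3, and their separate contributions remain open. Also open, going by these compounds, is how a primary amide or an amine would read on this group.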